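The compounds below may be only part of what the source reports. "The series", "measured", "known", "first", "only" and "open" are said of these compounds alone.

In an in vivo ADME assay on the whole organism for pharmacokinetics, with Rattus norvegicus as the target (on this read-out lower numbers stand for narrower distribution and higher numbers for wider distribution into tissues), compound 1 `Cc1cc(C(=O)NCc2ccccn2)nn1Cc1cc(Cl)ccc1OCc1ccccc1` gives 3.6 L/kg, level within the scatter with compound 2 `Cc1cc(NC(=O)C2CCCCC2)nn1Cc1cc(Cl)ccc1OCC(C)C` at 3.5 L/kg and compound 3 `Cc1cc(NC(=O)OCc2ccccn2)nn1Cc1cc(Cl)ccc1OCc1ccccc1` at 3 L/kg. Compound 4 `Cc1cc(NC(=O)O[C@H]2CCOC2)nn1Cc1cc(Cl)ccc1OCc1ccccc1` has not yet been measured. Its difference from compound 1 is: (((oxolan-3-yl)oxy)carbonyl)amino in place of ((pyridin-2-yl)methyl)carbamoyl on an aromatic carbon. The closest measured evidence is a 1.2-fold lower number from compound 1 to compound 3 (0.08 log units; within the scatter), where the same ((pyridin-2-yl)methyl)carbamoyl group gives way to (((pyridin-2-yl)methoxy)carbonyl)amino. Among the compounds with values here, no measured step covers the oxolan-3-yl ring, so the guidance is incomplete. On this evidence, no step beyond the scatter is expected in this assay, and any drift is tentatively expected to be downward. The estimated step is a 1.4-fold lower number from compound 1 to compound 4 (0.14 log units; within the scatter). The expected value for compound 4 is 2.6 L/kg, with an estimated range of 1.4 L/kg to 4.8 L/kg.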

Compound 4, volume of distribution at steady state: 3.7 L/kg
Estimate against measurement, compound 4: 1.4-fold (0.15 log units) below, and the stated range covers the measured number.
By their numbers in this assay, from the lowest: compounds 3, 2, 1 and 4 (each within the scatter of the next).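

In this assay, oxolan-3-yl in place of (pyridin-2-yl)methyl on an oxygen next to a carbonyl group gives a 1.2-fold higher number from compound 3 to compound 4 (0.09 log units; within the scatter), so in this pair the six-membered aromatic ring is not needed to keep the number within the scatter. With (((oxolan-3-yl)oxy)carbonyl)amino in place of ((pyridin-2-yl)methyl)carbamoyl on the aromatic carbon, the step is a 1.0-fold higher number from compound 1 to compound 4 (0.01 log units; within the scatter), so this five-membered non-aromatic ring also leaves the read-out level at this position. Nothing here gives a reason for this. Open, from the compounds shown here alone, is whether a carboxylic acid or a piperidin-4-yl ring in place of oxolan-3-yl would give a step beyond the scatter.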